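The compounds below may be only part of what the source reports. "The series", "measured", "known", "first", "only" and "open" are said of these compounds alone.

Measured so far:
- Compound 1, `Cc1c(CCOCCO[N+](=O)[O-])cc(-c2ccc(S(C)(=O)=O)cc2)n1-c1ccccc1`, gives 10 mg/kg in a functional assay on the whole organism (strain Swiss albino) with Mus musculus as the target, in the writhing test, with stated times of 5 min and 10 min; on this read-out higher numbers stand for an effect only at larger amounts of compound and lower numbers for an effect already at smaller amounts.
- Compound 2, `Cc1c(CCOCCO[N+](=O)[O-])cc(-c2ccc(S(C)(=O)=O)cc2)n1-c1cccc(F)c1`, gives 40 mg/kg in the same test.

Compound 2 stands at the highest of the two numbers, so among the two it needs the larger amount before an effect appears. Its nearest neighbour is compound 1, and the step between them is a 4.0-fold higher number from compound 1 to compound 2 (0.60 log units; beyond the scatter). Among the compounds with values here, that is the only measured step, and it is the one that bears on the next compound.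

Compound 3, `Cc1c(CCOCCO[N+](=O)[O-])cc(-c2ccc(S(C)(=O)=O)cc2)n1-c1ccc(F)c(F)c1`, is the not yet measured partner of compound 2. The change from compound 2 to compound 3 is fluoro in place of hydrogen on an aromatic carbon. Within the data shown here, the single measured step that bears on this change is a 4.0-fold higher number from compound 1 to compound 2 (0.60 log units; beyond the scatter), which is modest but clearly beyond the scatter. A second fluoro added to the same ring is expected to move the number in the same direction again, but by a smaller amount, so that the estimated step of a 1.5-fold higher number from compound 2 to compound 3 (0.18 log units; within the scatter) may not reach beyond the scatter. Compound 3 is therefore estimated at 60 mg/kg, with a range from 20 mg/kg to 160 mg/kg.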

Compound 3, minimum effective dose: 20 mg/kg
Compound 3: the middle estimate sits 3.0-fold (0.48 log units) above what was measured; the measured number falls inside the stated range.
By their numbers in this assay, from the lowest: compounds 1, 3 and 2 (each within the scatter of the next, the first and the last beyond it).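

In this assay, fluoro entering the 3-fluorophenyl group, ortho to a fluoro group and para to a large group, gives a 2.0-fold lower number from compound 2 to compound 3 (0.30 log units; within the scatter); this step lies within the scatter and so does not repeat the earlier 4.0-fold higher number from compound 1 to compound 2 (0.60 log units; beyond the scatter), which lay beyond it. Taken whole, the change to 3,4-difluorophenyl gives a 2.0-fold higher number from compound 1 to compound 3 (0.30 log units; within the scatter), also within the scatter, so compound 3 cannot be told apart from either compound 1 or compound 2, even though those two are separated by more than the scatter. The same swap of hydrogen for fluoro on this ring therefore does not give one fixed outcome across these compounds, and no measurement shown here accounts for that.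

As far as these compounds go, with only hydrogen or fluoro on the ring so far, it remains open how 4-fluorophenyl alone would compare with phenyl, which would show what the fluoro at this place does without the neighbouring one. From the compounds shown here alone, it also remains open whether a chloro or a methoxy group in the same place would read like fluoro in this test.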